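The compounds below may be only part of what the source reports. "The series", "measured", "known", "first", "only" and "open" are said of these compounds alone.

Measured compounds:
compound 1 `COc1ccc(S(=O)(=O)c2cnc3cc(F)ccc3c2N2CCC(C)CC2)cc1` with 90%
compound 2 `CC1CCN(c2c(S(=O)(=O)c3cccc(C#N)c3)cnc3cc(F)ccc23)CC1` with 92%

Of the compounds shown here, two have been measured in an assay on isolated protein for displacement of a labelled ligand from metabotropic glutamate receptor 5 (Homo sapiens), with a stated time of 60 min, tested at 1 uM; on this read-out higher numbers stand for more inhibition at the one concentration tested (going by the name of the read-out) and lower numbers for less inhibition. Compound 1 gives 90%. Compound 2 gives 92%, the higher of the two numbers, though its lead over compound 1 is only a number 2 percentage points higher from compound 1 to compound 2 (within the scatter) and so within the scatter. Going by the values given here, the only change between them is on the aryl group attached to the sulfonyl sulfur, and that swap left this assay essentially unmoved.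

Compound 3 `CC1CCN(c2c(S(=O)(=O)c3ccc(F)cc3)cnc3cc(F)ccc23)CC1` is the next compound, not yet measured. It differs from compound 2 in one place: 4-fluorophenyl in place of 3-cyanophenyl on a sulfonyl sulfur. Among the compounds with values here, the single step that bears on this change is the one on the same sulfonyl aryl group, the step of a number 2 percentage points higher from compound 1 to compound 2 (within the scatter), which stayed within the scatter. On that basis no step beyond the scatter is expected, and compound 3 is estimated at 88%, with a range of 72% to 98%, an expected step of a number 4 percentage points lower from compound 2 to compound 3 (within the scatter).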

Compound 3, a percentage reported as inhibition, at one concentration (the size of the read-out at that concentration, not a potency): 74.5%
The estimate for compound 3 lay 13.5 percentage points above the measured number, and the stated range covers the measured number.
By their numbers in this assay, from the lowest: compound 3; then compounds 1 and 2 (each within the scatter of the next).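

In this assay, the aryl group on the sulfonyl sulfur proves able to change the result: 4-fluorophenyl in place of 3-cyanophenyl gives a number 17.5 percentage points lower from compound 2 to compound 3 (beyond the scatter) and fluoro in place of methoxy on an aromatic carbon gives a number 15.5 percentage points lower from compound 1 to compound 3 (beyond the scatter) as well. The earlier swap of 4-methoxyphenyl for 3-cyanophenyl stayed within the scatter, so compounds 1 and 2 alone gave no sign that this place responds to its substituent, whereas both steps to compound 3 lie beyond it. No measurement available here accounts for this difference.

With only three aryl groups shown, it remains open whether the fall is specific to fluoro or would also follow from a chloro or a methyl group on the phenyl ring. Also open, going by these compounds, is how a saturated ring such as cyclohexyl would fare on the sulfonyl sulfur.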